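Smaller Fluorinated Ring Replaces the Trifluoromethylphenyl Group

A few compounds are considered here, and "the series" means these few. Any claim that something is new, unique, unknown or untested is made for them only; others in the source may bear on it.

Compound 3 `CN(C(=O)NC(=O)c1ccc(C(F)(F)F)cc1)c1nc(C(F)(F)F)c(C(=O)N/N=C/c2ccc(C(F)(F)F)cc2)s1` reaches only a limit in a functional assay on BCG823 cells (Homo sapiens) for inhibition, read by MTT assay, with a stated time of 72 h (on this read-out lower numbers stand for stronger inhibition and higher numbers for weaker inhibition), reported as > 100 ug/mL. Compound 2 `CN(C(=O)NC(=O)c1ccc(Cl)cc1Cl)c1nc(C(F)(F)F)c(C(=O)N/N=C/c2ccc(C(F)(F)F)cc2)s1` gives 3.08 ug/mL, so the step of an at least 32-fold higher number from compound 2 to compound 3 (1.51 log units; beyond the scatter) carries the number up to the assay ceiling (the limit of > 100 ug/mL in this assay, at which 1 of the 3 values shown sits). Compound 1 `Cc1nc(N(C)C(=O)NC(=O)c2c(F)cccc2F)sc1C(=O)N/N=C/c1ccc(C(F)(F)F)cc1`, which carries a 2,6-difluorophenyl ring on a different core, gives 65.5 ug/mL. Compound 4 `CN(C(=O)NC(=O)c1c(F)cccc1F)c1nc(C(F)(F)F)c(C(=O)N/N=C/c2ccc(C(F)(F)F)cc2)s1` arises from compound 3 by 2,6-difluorophenyl in place of 4-(trifluoromethyl)phenyl on a carbonyl carbon. Within the data shown here, no measured step makes exactly this exchange; the step from compound 2 to compound 3 shows that the ring on this carbonyl carbon can move the number greatly, while compound 1 shows that a 2,6-difluorophenyl ring can sit at a middling value. Compound 4 is therefore expected near 30 ug/mL, within 8 ug/mL to 100 ug/mL, an expected gain of an at least 3.3-fold lower number from compound 3 to compound 4 (0.52 log units; beyond the scatter).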

Compound 4, half-maximal inhibitory concentration: 34.9 ug/mL
The estimate for compound 4 lay 1.2-fold (0.07 log units) below the measured number; low and high end bracket the measured number.
By their numbers in this assay, from the lowest: compound 2; then compounds 4 and 1 (each within the scatter of the next). At a limit, above all of these: compound 3.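

Compound 3 is a limit and not a number, so an at least 2.8-fold lower number from compound 3 to compound 4 (0.45 log units; beyond the scatter) is a minimum: on the shared core, the 2,6-difluorophenyl ring on this carbonyl carbon gives a measurable value in this assay. That ring still falls short of the 2,4-dichlorophenyl ring, with an 11-fold higher number from compound 2 to compound 4 (1.05 log units; beyond the scatter). Methyl and trifluoromethyl on an aromatic carbon cannot be told apart here, with a 1.9-fold lower number from compound 1 to compound 4 (0.27 log units; within the scatter). As far as these compounds go, how a phenyl ring carrying an amine or a methoxy group would behave on this carbonyl carbon stays open, as does whether the 2,4-dichlorophenyl ring would keep its number with methyl on the core.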